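Methyl for isopropyl on an aromatic carbon

The compounds below may be only part of what the source reports. "The series", "measured", "known", "first", "only" and "open" are said of these compounds alone.

In a functional assay on PC-3 cells (Homo sapiens) for antiproliferative activity, read by MTT assay, with a stated time of 48 h (a lower number here means a stronger inhibitor, a higher number a weaker inhibitor), compound 1 `O=C(/C=C/c1ccc(/C=C/C(=O)c2cccc(Cl)c2)o1)NO` gives 9600 nM and compound 2 `CC(C)c1ccc(C(=O)/C=C/c2ccc(/C=C/C(=O)NO)o2)cc1` gives 2270 nM. Compound 2 thus holds the lower of the two numbers, by a gap beyond the usual scatter. Compound 3 `Cc1ccc(C(=O)/C=C/c2ccc(/C=C/C(=O)NO)o2)cc1` has methyl in place of isopropyl on an aromatic carbon, para to a large group: methyl in place of isopropyl on an aromatic carbon. Within the data shown here, no measured pair shows this change, so no step beyond the scatter is expected, with any drift slightly upward. The estimated change is a 1.2-fold higher number from compound 2 to compound 3 (0.09 log units; within the scatter). Compound 3 is expected at 2800 nM, with an estimated range of 1100 nM to 7000 nM.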

Compound 3, half-maximal inhibitory concentration: 16000 nM
The estimate for compound 3 lay 5.7-fold (0.76 log units) below the measured number; measured number above the stated range.
By their numbers in this assay, from the lowest: compound 2; then compounds 1 and 3 (each within the scatter of the next).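

At this position on the aromatic ring, para to a large group, the size of the step in this assay shows that the alkyl group counts: methyl in place of isopropyl gives a 7.0-fold higher number from compound 2 to compound 3 (0.85 log units; beyond the scatter), beyond the scatter. Replacing the whole aryl group, with 4-methylphenyl in place of 3-chlorophenyl on a carbonyl carbon, gives only a 1.7-fold higher number from compound 1 to compound 3 (0.22 log units; within the scatter), so compound 1 and compound 3 cannot be told apart here. No available measurement accounts for the step from isopropyl to methyl. Going by these compounds, whether a tert-butyl group, a longer alkyl chain or an amine at this position would match or improve on compound 2 remains open.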